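This account rests on a few compounds, and the source may have more. Where it says the series, first, only, none or still open, it means among the compounds named here.

In a functional assay on HepG2 cells (Homo sapiens) for inhibition, read by CCK-8 assay, with a stated time of 48 h (a lower number here means a stronger inhibitor, a higher number a weaker inhibitor), compound 1 (`Cc1ccc(C2=NN(C3=NC(c4ccccc4)CS3)C(c3ccc4ccccc4c3)C2)cc1`) gives 14700 nM, compound 2 (`O=C1CSC(N2N=C(c3ccc(Cl)cc3)CC2c2cccc3ccccc23)=N1`) gives 16500 nM and compound 3 (`Cc1ccc(C2=NN(C3=NC(=O)CS3)C(c3ccc4ccccc4c3)C2)cc1`) gives 12700 nM, so compound 3 stands within the scatter of both others. Compound 4 (`O=C1CSC(N2N=C(c3ccc(Cl)cc3)CC2c2ccc3ccccc3c2)=N1`) differs from compound 3 by chloro in place of methyl on an aromatic carbon, 4-methylphenyl to 4-chlorophenyl. Going by the values given here, no measured step shows this change. Among the compounds with values here, the one measured step, a 1.2-fold lower number from compound 1 to compound 3 (0.06 log units; within the scatter), lies at another place, on an amine nitrogen in a ring. Compound 2 also carries a chloro group, yet its value lies within the scatter of compound 3. No shift beyond the scatter is therefore expected in this assay. The expected change is a 1.0-fold higher number from compound 3 to compound 4 (0.01 log units; within the scatter). For compound 4 the estimated value is 13000 nM, with an expected range of 7000 nM to 24000 nM.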

Compound 4, half-maximal inhibitory concentration: 20400 nM
Beside the measured number, compound 4's estimate is 1.6-fold (0.20 log units) below it; the measured number falls inside the stated range.
By their numbers in this assay, from the lowest: compounds 3, 1, 2 and 4 (each within the scatter of the next).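

In this assay the exchange of methyl for chloro on an aromatic carbon, para to a large group, gives a 1.6-fold higher number from compound 3 to compound 4 (0.21 log units; within the scatter). Going by these compounds alone, this is the first reading at this position, since the earlier step lay on an amine nitrogen in a ring, and here too the change stays within the scatter. Nothing measured here gives a reason for this step. Still open, as far as these compounds go, is whether an amine or a carboxylic acid at this same place would shift the number beyond the scatter.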